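Removing the acetamido group from compound 1

The source may hold more compounds than are shown below. What is called first, only, known or untested is meant among the compounds shown, and "the series" means these compounds.

In a functional assay on SW480 cells (Homo sapiens) for cytotoxicity, read by sulforhodamine B assay, with a stated time of 48 h (on this read-out higher numbers stand for weaker inhibition and lower numbers for stronger inhibition), compound 1 `COc1ccc(/C=C/C(=O)c2ccc(NC(C)=O)c(-c3ccc(F)cc3)c2)cc1OC` gives 5350 nM while compound 2 `COc1cc(/C=C/C(=O)c2ccc(N)c(-c3ccc(F)cc3)c2)ccc1O` gives 8350 nM and these two values lie within the usual scatter of each other. Compound 1 therefore cannot be set apart from compound 2 on these numbers, and only these two values are available so far.

Compound 3 `COc1ccc(/C=C/C(=O)c2cccc(-c3ccc(F)cc3)c2)cc1OC` keeps the core of compound 1 but carries hydrogen in place of acetamido on an aromatic carbon, ortho to a 4-fluorophenyl group and para to a large group (hydrogen in place of acetamido on an aromatic carbon). Among the measured compounds shown here, no pair of measured compounds differs in this one place alone, so the data give no direct size for this change. From the compounds shown here alone, the two measured compounds do not show how much the acetamido group contributes, and the direction of any shift remains open. In this assay the expected step is a 1.3-fold higher number from compound 1 to compound 3 (0.12 log units; within the scatter) and no change beyond the scatter is expected. The estimated value for compound 3 is 7000 nM with an expected range (2500 nM to 20000 nM).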

Compound 3, half-maximal inhibitory concentration: 6490 nM
The estimate for compound 3 lay 1.1-fold (0.03 log units) above the measured number; low and high end bracket the measured number.
By their numbers in this assay, from the lowest: compounds 1, 3 and 2 (each within the scatter of the next).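

Among the compounds shown here, on this aromatic carbon, ortho to a 4-fluorophenyl group and para to a large group, compound 1 and compound 3 differ in one place alone, which gives the first direct reading of this change. In this assay the step for hydrogen in place of acetamido is a 1.2-fold higher number from compound 1 to compound 3 (0.08 log units; within the scatter) and so the read-out does not separate the two compounds: the acetamido group, with its 4 heavy atoms, can give way to a hydrogen atom on the core of compound 1 without a shift beyond the scatter in this assay. No measurement at hand bears on why the two compounds read alike.

From the compounds shown here alone, whether a carboxylic acid or a nitrile on this same carbon would give a number beyond the scatter of these values remains open. Compound 2 differs from compound 1 in more than one place, so it cannot show whether this step would stay the same with a different substitution on the other aromatic ring of the core.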